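The compounds below may be only part of what the source reports. "The series", "measured", "known", "first", "only" and "open" are said of these compounds alone.

Measured in a functional assay on HEK293 cells for activation of melanin-concentrating hormone receptor 1 (Rattus norvegicus), read by inositol phosphate accumulation; a lower number here means that less compound is needed, a higher number that more compound is needed for the effect:
- compound 1, `O=C(CCc1ccc(C(F)(F)F)cc1)Nc1ccc2nc(N3CC4CC3CN4)ccc2c1`: compound 1 gives 490 nM
- compound 2, `CN(c1ccc2cc(NC(=O)CCc3ccc(C(F)(F)F)cc3)ccc2n1)C1CCCCC1`: compound 2 gives 1200 nM
- compound 3, `CN(c1ccc2cc(NC(=O)CCc3ccc(C(F)(F)F)cc3)ccc2n1)C1CCCC1`: compound 3 gives 350 nM

Compound 3 shows the lowest of the three numbers in this assay, but its separation from compound 1 is a 1.4-fold lower number from compound 1 to compound 3 (0.15 log units; within the scatter), so the two cannot be ordered; only compound 2 is clearly apart, with a 3.4-fold lower number from compound 2 to compound 3 (0.54 log units; beyond the scatter).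

Compound 4, `CC(=O)NC1CCN(c2ccc3cc(NC(=O)CCc4ccc(C(F)(F)F)cc4)ccc3n2)C1`, carries 3-acetamidopyrrolidin-1-yl in place of cyclopentyl(methyl)amino on an aromatic carbon. Among the measured compounds shown here, two measured steps bear on this. The exchange of the bicyclic diamine of compound 1 for the cyclopentyl(methyl)amino group was a 1.4-fold lower number from compound 1 to compound 3 (0.15 log units; within the scatter), so a five-membered ring bearing a second nitrogen and a five-membered ring of carbon only gave numbers of the same order. The ring size itself mattered more: a 2.4-fold higher number from compound 1 to compound 2 (0.39 log units; beyond the scatter) and a 3.4-fold lower number from compound 2 to compound 3 (0.54 log units; beyond the scatter). For the measured compounds named here, the incoming 3-acetamidopyrrolidin-1-yl group keeps a five-membered ring with one hetero atom, as in compound 1, and adds an acetamide with one hydrogen-bond donor, for which no measured step exists. On that basis compound 4 is expected to stay close to compound 3 in this assay, with a 1.4-fold higher number from compound 3 to compound 4 (0.15 log units; within the scatter) likely small or within the scatter; the estimate for compound 4 is 500 nM, in the range 180 nM to 1500 nM.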

Compound 4, half-maximal effective concentration: 440 nM
Estimate against measurement, compound 4: 1.1-fold (0.06 log units) above, and the stated range covers the measured number.
By their numbers in this assay, from the lowest: compounds 3, 4 and 1 (each within the scatter of the next); then compound 2.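

At the aromatic carbon next to the ring nitrogen, the larger 3-acetamidopyrrolidin-1-yl group, which brings an acetamide onto a five-membered ring, is accepted in this assay without a readable shift, with a 1.3-fold higher number from compound 3 to compound 4 (0.10 log units; within the scatter) and with a 1.1-fold lower number from compound 1 to compound 4 (0.05 log units; within the scatter). The separation from the cyclohexyl compound also extends to this group, with a 2.7-fold lower number from compound 2 to compound 4 (0.44 log units; beyond the scatter), so compound 2 stands apart from all three compounds that carry a five-membered ring at this position. No supporting measurement accompanies these numbers, so this remains a description of the series only.

Still open, as far as these compounds go, is whether the acetamide contributes anything of its own, which a plain pyrrolidin-1-yl or a 3-aminopyrrolidin-1-yl group at the same carbon would separate from the contribution of the ring. Also open, from the compounds shown here alone, is how far this position accepts other substituents on the five-membered ring, such as a carboxylic acid or a longer chain, and whether the same pattern would hold with a different amide side chain on the shared core.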